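Trifluoromethoxy in place of acetoxy on the aromatic ring

The compounds below may be only part of what the source reports. "The series", "measured", "known", "first", "only" and "open" are said of these compounds alone.

Compound 1 `C=CC[C@H]1C[C@]2([C@@H](C)Cc3ccc(OC)cc3)OCOC2=CC1=O` gives 20 nM in a functional assay on M14 cells (Homo sapiens) for antiproliferative activity, with a stated time of 72 h; on this read-out lower numbers stand for stronger inhibition and higher numbers for weaker inhibition.
Compound 2 `C=CC[C@H]1C[C@]2([C@@H](C)Cc3ccccc3)OCOC2=CC1=O` gives 5100 nM in this assay.
Compound 3 `C=CC[C@H]1C[C@]2([C@@H](C)Cc3ccc(OC(C)=O)cc3)OCOC2=CC1=O` gives only a limit of the assay, > 20000 nM, in this assay.

Compound 3 thus stands at the high end of the three, its value being a limit (the limit of > 20000 nM in this assay, at which 1 of the 3 values shown sits), and both steps to it, an at least 1000-fold higher number from compound 1 to compound 3 (3.00 log units; beyond the scatter) and an at least 3.9-fold higher number from compound 2 to compound 3 (0.59 log units; beyond the scatter), lie beyond the scatter. Compound 4 `C=CC[C@H]1C[C@]2([C@@H](C)Cc3ccc(OC(F)(F)F)cc3)OCOC2=CC1=O` differs from compound 3 by trifluoromethyl in place of acetyl on an oxygen on an aromatic ring. For the measured compounds named here, no measured step carries a trifluoromethyl group, so the bearing comes from the neighbours: a 260-fold higher number from compound 1 to compound 2 (2.41 log units; beyond the scatter) shows how much the methoxy group contributes, and an at least 1000-fold higher number from compound 1 to compound 3 (3.00 log units; beyond the scatter) shows that an acetyl on that oxygen removes it entirely. Compound 4 keeps an oxygen on the ring with a small group on it, unlike the acetyl of compound 3, so the expectation is a lower number than the limit of compound 3, roughly near the level of compound 2, as an at least 5.0-fold lower number from compound 3 to compound 4 (0.69 log units; beyond the scatter). Compound 4 is estimated at 4000 nM in this assay, within 500 nM to 20000 nM.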

Compound 4, half-maximal inhibitory concentration: > 20000 nM
Compound 4: a limit, no number (the forecaster's own chance of this, stated with the estimate: 30%); middle value at least 5.0-fold (0.69 log units) away from the limit.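

In this assay compound 4 gives only a limit of the assay, as compound 3 does, and the step between them cannot be read: the limit of > 20000 nM in this assay, at which 2 of the 4 values shown sit. An oxygen on the aromatic ring is therefore not enough on its own: trifluoromethyl in place of methyl on that oxygen gives an at least 1000-fold higher number from compound 1 to compound 4 (3.00 log units; beyond the scatter), a loss that matches in printed size the one seen with acetyl, an at least 1000-fold higher number from compound 1 to compound 3 (3.00 log units; beyond the scatter). Trifluoromethoxy also falls behind plain hydrogen on that aromatic carbon, with an at least 3.9-fold higher number from compound 2 to compound 4 (0.59 log units; beyond the scatter), so among the four compounds only the methoxy group of compound 1 goes with the strong inhibition.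

The compounds shown leave open whether a hydroxyl, an ethoxy group or an amine on that aromatic carbon would keep any of it. They also do not show whether methoxy at this place could be matched by any other group.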